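The source may hold more compounds than are shown below. What is called first, only, known or untested is meant among the compounds shown, and "the series" means these compounds.

Measured compounds in a functional assay on DU-145 cells (Homo sapiens) for cytotoxicity, read by MTT assay, with a stated time of 72 h; on this read-out lower numbers stand for stronger inhibition and higher numbers for weaker inhibition:
compound 1, `COc1cc(OC)cc(/C(=C\c2cn(C(C)=O)c3ccc(OCc4ccccc4)cc23)C(=O)O)c1`, 880 nM
compound 2, `O=C(O)/C(=C/c1c[nH]c2ccc(OCc3ccccc3)cc12)c1ccccc1`, 34700 nM
compound 3, `COc1ccc(/C(=C\c2c[nH]c3ccc(OCc4ccccc4)cc23)C(=O)O)cc1`, 38100 nM

Compound 2 stands second highest of the three numbers; its nearest neighbour is compound 3, a 1.1-fold higher number from compound 2 to compound 3 (0.04 log units; within the scatter), and its furthest is compound 1, whose number is far lower.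

Compound 4 is `COc1ccc(Cn2cc(/C=C(/C(=O)O)c3ccccc3)c3cc(OCc4ccccc4)ccc32)cc1`, not yet measured. It differs from compound 2 in one place: 4-methoxybenzyl in place of hydrogen on an aromatic nitrogen.

Among the measured compounds shown here, no measured step bears directly on this change. For the measured compounds named here, the only step recorded, methoxy in place of hydrogen on an aromatic carbon, is a 1.1-fold higher number from compound 2 to compound 3 (0.04 log units; within the scatter) and says nothing about the aromatic nitrogen. Compound 1 does carry a group on that nitrogen and gives a much lower number, but it differs from compound 2 in more than one place, so its value cannot be read as a step. On this basis only a loose expectation is possible: a lower number, of uncertain size, is expected for compound 4, a 2.9-fold lower number from compound 2 to compound 4 (0.46 log units; beyond the scatter). Compound 4 is therefore estimated at 12000 nM, within 3000 nM to 50000 nM.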

Compound 4, half-maximal inhibitory concentration: 860 nM
Estimate against measurement, compound 4: 14-fold (1.14 log units) above; the whole stated range lies above it.
By their numbers in this assay, from the lowest: compounds 4 and 1 (each within the scatter of the next); then compounds 2 and 3 (each within the scatter of the next).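

In this assay, among the compounds shown here, the aromatic nitrogen of the five-membered ring is the first place where a single change moves the number beyond the scatter: 4-methoxybenzyl in place of hydrogen gives a 40-fold lower number from compound 2 to compound 4 (1.61 log units; beyond the scatter) and is read as a large step. For the compounds shown here, the only earlier single change, methoxy in place of hydrogen on an aromatic carbon, gave a 1.1-fold higher number from compound 2 to compound 3 (0.04 log units; within the scatter) and stayed within the scatter, so the two compounds with a free nitrogen-hydrogen gave no sign of this sensitivity. No evidence is available on why the step is this large.

From the compounds shown here alone, whether the step needs the 4-methoxybenzyl group, or its methoxy, remains open; plain benzyl, methyl or a longer chain ending in an amine on the same nitrogen would separate these cases. Going by these compounds, whether the step holds when the carboxylic acid is replaced by an ester or amide also remains open.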